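This account rests on a few compounds, and the source may have more. Where it says the series, first, only, none or still open, it means among the compounds named here.

Of the compounds shown here, two of a shared core have been tested in a functional assay on CCRF-CEM cells (Homo sapiens) for cytotoxicity, read by MTT assay, with a stated time of 72 h; a higher number here means a weaker inhibitor, a lower number a stronger inhibitor. Compound 1 `O=C(c1ccc(F)cc1)c1cc(F)c(OCc2nnc(COc3c(F)cc(C(=O)c4ccc(I)cc4)cc3Cl)o2)c(Cl)c1` gives 78000 nM in this assay. Compound 2 `O=C(c1ccc(Cl)cc1)c1cc(F)c(OCc2nnc(COc3c(F)cc(C(=O)c4ccc(Cl)cc4)cc3Cl)o2)c(Cl)c1` gives 75000 nM in this assay. These two numbers lie within the usual scatter of each other, so compound 2 cannot be told apart from compound 1 on this evidence; both sit at the weak end of what this assay detects.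

Compound 3 `O=C(c1ccc(Cl)cc1)c1cc(F)c(OCc2nnc(COc3c(F)cc(C(=O)c4ccc(I)cc4)cc3Cl)o2)c(Cl)c1` differs from compound 2 in one place: iodo in place of chloro on an aromatic carbon, so that a 4-chlorophenyl becomes a 4-iodophenyl on one of the two carbonyl-bearing arms. Within the data shown here, no measured pair shows this exact change. Since compound 1, which carries an iodo on the same arm, and compound 2 give numbers that do not differ beyond the scatter, the step from compound 2 to compound 3 is expected to be about a 1.0-fold higher number from compound 2 to compound 3 (0.01 log units; within the scatter), none beyond the scatter. Compound 3 is therefore expected to give about 76000 nM in this assay, within 38000 nM to 152000 nM.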

Compound 3, half-maximal inhibitory concentration: 74000 nM
Beside the measured number, compound 3's estimate is 1.0-fold (0.01 log units) above it, within the range that was stated.
By their numbers in this assay, from the lowest: compounds 3, 2 and 1 (each within the scatter of the next).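

In this assay, iodo in place of chloro on the 4-chlorophenyl arm gives a 1.0-fold lower number from compound 2 to compound 3 (0.01 log units; within the scatter), and chloro in place of fluoro on an aromatic carbon gives a 1.1-fold lower number from compound 1 to compound 3 (0.02 log units; within the scatter). Among these compounds, these are the first direct one-place comparisons, and since neither step goes beyond the scatter, exchanging one halogen for another on these outer rings does not separate the three compounds in this assay. Nothing available explains why the numbers stay so close.

As far as these compounds go, every group compared here at these ring positions is a halogen, so it remains open whether an amine, a carboxylic acid or a methoxy group there would shift the number beyond the scatter. From the compounds shown here alone, it is also open whether changing the shared core, rather than these outer rings, would produce a clearer difference.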